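Compound 3 to compound 4: a new chlorophenyl group

This account rests on a few compounds, and the source may have more. Where it says the series, first, only, none or still open, it means among the compounds named here.

Values in a functional assay on HepG2 cells (Homo sapiens) for inhibition, read by MTT assay, with a stated time of 24 h; a higher number here means a weaker inhibitor, a lower number a stronger inhibitor:
- Compound 1 `CC1(C)[C@H]2CC[C@]1(C)N(Cc1cn(-c3ccc(C#N)cc3)nn1)C(=O)C2`: 50 nM
- Compound 2 `CC1(C)[C@H]2CC[C@]1(C)N(Cc1cn(-c3ccccc3C#N)nn1)C(=O)C2`: 180 nM
- Compound 3 `CC1(C)[C@H]2CC[C@]1(C)N(Cc1cn(-c3ccccc3F)nn1)C(=O)C2`: 60 nM

Compound 3 stands at the low end of these numbers, level with compound 1 and clear of compound 2. The measured steps show this: a 1.2-fold higher number from compound 1 to compound 3 (0.08 log units; within the scatter), while a 3.0-fold lower number from compound 2 to compound 3 (0.48 log units; beyond the scatter).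

Compound 4 `CC1(C)[C@H]2CC[C@]1(C)N(Cc1cn(-c3cccc(Cl)c3)nn1)C(=O)C2` has 3-chlorophenyl in place of 2-fluorophenyl on an aromatic nitrogen. Among the compounds with values here, no measured compound carries chlorine, so the earlier steps offer only loose guidance. Changing the group on this nitrogen can matter, as a 3.6-fold higher number from compound 1 to compound 2 (0.56 log units; beyond the scatter) shows. Yet a change of both group and ring location can also leave the number in place, as a 1.2-fold higher number from compound 1 to compound 3 (0.08 log units; within the scatter) shows. In this assay, a step beyond the scatter is therefore not expected, although one of modest size in either direction remains possible. The expected step is a 1.2-fold higher number from compound 3 to compound 4 (0.07 log units; within the scatter). For compound 4 the estimated value is 70 nM, with an expected range of 25 nM to 200 nM.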

Compound 4, half-maximal inhibitory concentration: 60 nM
The estimate for compound 4 lay 1.2-fold (0.07 log units) above the measured number; low and high end bracket the measured number.
By their numbers in this assay, from the lowest: compounds 1, 3 and 4 (each within the scatter of the next); then compound 2.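

In this assay, putting 3-chlorophenyl in place of 2-fluorophenyl on this aromatic nitrogen leaves the number where it was (no change at the digits printed from compound 3 to compound 4 (within the scatter)), so a chlorine-bearing ring joins the group with the lowest numbers. The comparison with the 4-cyanophenyl ring agrees (a 1.2-fold higher number from compound 1 to compound 4 (0.08 log units; within the scatter)), which leaves three differently substituted phenyl rings level, while the 2-cyanophenyl ring alone stands apart (a 3.0-fold lower number from compound 2 to compound 4 (0.48 log units; beyond the scatter)). No measured property is available to explain why these rings sit level or why that one differs.

The compounds shown leave open whether an amine or a carboxylic acid on the phenyl ring, or a pyridine ring in its place, would keep the number this low. Going by these compounds, it also remains open whether the gap seen with 2-cyanophenyl belongs to the nitrile itself or to something else.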